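The compounds below may be only part of what the source reports. "The series", "measured", "known", "first", "only" and "open" are said of these compounds alone.

Compound 1 `Cc1cc(O)c(C2=NN(c3ccc(S(N)(=O)=O)cc3)C(c3ccccc3O)C2)cc1Cl`: 1730 nM
Compound 2 `Cc1cc(O)c(C2=NN(c3ccc(S(N)(=O)=O)cc3)C(/C=C/c3ccccc3)C2)cc1Cl`: 3940 nM
Compound 3 `COc1ccc(C2CC(c3cc(Cl)c(C)cc3O)=NN2c2ccc(S(N)(=O)=O)cc2)cc1OC`: 3350 nM

Of the compounds shown here, three built on one shared core have been measured in a functional assay on LOX IMVI cells (Homo sapiens) for antiproliferative activity, with a stated time of 48 h; a higher number here means a weaker inhibitor of growth, a lower number a stronger inhibitor of growth. Among them, compound 3 stands with the second highest number. Its value and that of compound 2 lie within the scatter of each other, the step between them being a 1.2-fold lower number from compound 2 to compound 3 (0.07 log units; within the scatter), and the gap to compound 1, a 1.9-fold higher number from compound 1 to compound 3 (0.29 log units; within the scatter), also stays within the scatter. Among the measured compounds shown here, only one step among the measured compounds reaches beyond it, namely a 2.3-fold higher number from compound 1 to compound 2 (0.36 log units; beyond the scatter).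

Compound 4 `COc1ccc(C2CC(c3cc(Cl)c(C)cc3O)=NN2c2ccc(S(N)(=O)=O)cc2)c(OC)c1OC` differs from compound 3 in one place: methoxy in place of hydrogen on an aromatic carbon. For the measured compounds named here, no measured step adds a group to this aromatic ring; the steps that come closest exchange the whole group on the saturated ring carbon, and both of them, a 1.9-fold higher number from compound 1 to compound 3 (0.29 log units; within the scatter) and a 1.2-fold lower number from compound 2 to compound 3 (0.07 log units; within the scatter), stay within the scatter. This assay therefore offers nothing that would point to a change beyond the scatter in either direction, and the expected step, a 1.0-fold higher number from compound 3 to compound 4 (0.02 log units; within the scatter), is one that stays within it. In this assay compound 4 is accordingly expected to give about 3500 nM, with a range from 1700 nM to 7200 nM.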

Compound 4, concentration for 50% growth inhibition: 2080 nM
For compound 4 the middle estimate is 1.7-fold (0.23 log units) above the measured one; the measured number falls inside the stated range.
By their numbers in this assay, from the lowest: compounds 1, 4, 3 and 2 (each within the scatter of the next, the first and the last beyond it).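

In this assay, methoxy in place of hydrogen on an aromatic carbon, ortho to a large group and ortho to a methoxy group, is the only step shown that adds a group to this aromatic ring, and with a 1.6-fold lower number from compound 3 to compound 4 (0.21 log units; within the scatter) as its size it shows that this position takes the added methoxy without a change beyond the scatter. Exchanges of the whole group on the saturated ring carbon agree with this: 2,3,4-trimethoxyphenyl in place of 2-phenylethenyl gives a 1.9-fold lower number from compound 2 to compound 4 (0.28 log units; within the scatter) and 2,3,4-trimethoxyphenyl in place of 2-hydroxyphenyl gives a 1.2-fold higher number from compound 1 to compound 4 (0.08 log units; within the scatter) as well, so compound 4 lies within the scatter of each of the other three compounds. No evidence is at hand that bears on this result.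

On these data alone, whether an amine or a carboxylic acid on this same aromatic carbon would also stay within the scatter in this assay remains open. As far as these compounds go, it is equally open whether a longer chain, such as ethoxy, would do so in place of the added methoxy.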